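Shortening an Amide Substituent on Compound 1

The source may report more compounds than this note shows. Statements on the series, on what has been measured and on what is new or still open speak of the compounds shown alone.

Going by the values given here, in a functional assay on NCI-H1975 cells (Homo sapiens) for antiproliferative activity, read by CCK-8 assay, with a stated time of 72 h (a lower number here means a stronger inhibitor of growth, a higher number a weaker inhibitor of growth), compound 1 `CCC1C(=O)N(C)c2cnc(-n3ccc4cc(C(=O)NC(C)C)ccc43)nc2N1c1ccn(C)n1` gives 12200 nM, the higher of the two numbers measured so far and beyond the scatter from the other. That other number belongs to compound 2 `CC[C@@H]1C(=O)N(C)c2cnc(Nc3ccc(S(=O)(=O)NC)cc3)nc2N1C1CCCC1`, which gives 1410 nM. Compound 3 `CCC1C(=O)N(C)c2cnc(-n3ccc4cc(C(=O)NC)ccc43)nc2N1c1ccn(C)n1` keeps the rest of compound 1 but carries methyl in place of isopropyl on an amide-type nitrogen. Among the compounds with values here, no measured pair tests this change. The expected step is a 1.4-fold lower number from compound 1 to compound 3 (0.13 log units; within the scatter), a slightly lower number that stays within the scatter. The estimated value for compound 3 is 9000 nM, with an expected range from 3500 nM to 20000 nM.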

Compound 3, concentration for 50% growth inhibition: 35700 nM
Compound 3: the middle estimate sits 4.0-fold (0.60 log units) below what was measured; the whole stated range lies below it.
By their numbers in this assay, from the lowest: compound 2; then compound 1; then compound 3.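

In this assay the substituent on this amide-type nitrogen matters: methyl in place of isopropyl gives a 2.9-fold higher number from compound 1 to compound 3 (0.47 log units; beyond the scatter), so here the smaller group goes with weaker growth inhibition. The change takes the substituent from 3 heavy atoms to 1, all carbon, and alters no hydrogen-bond donor or acceptor count. No measurement shown explains this step.

A single pair cannot show a trend. From the compounds shown here alone, whether a tert-butyl group or a longer chain on this nitrogen would give a lower number than compound 1 remains open.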